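Permeability step from compound 2 to compound 3

This account rests on a few compounds, and the source may have more. Where it says the series, first, only, none or still open, it means among the compounds named here.

Measured so far:
compound 1, `O=C(O)CCCc1cn(CC(=O)O)c2c(/C=C/c3ccc(OCCCCc4c(F)ccc(F)c4F)cc3)cccc12`, 1.4 10^-6 cm/s
compound 2, `Cc1c(CCCC(=O)O)c2cccc(/C=C/c3ccc(OCCCCc4c(F)c(F)cc(F)c4F)cc3)c2n1CC(=O)O`, 9.4 10^-6 cm/s

Of the compounds shown here, two have been measured in a physicochemical assay for permeability, using PAMPA, with a stated time of 4 h, at pH 6.2, tested at 50 uM; a lower number here means that the compound crosses the layer more slowly, a higher number that the compound crosses the layer faster. Compound 1, with structure `O=C(O)CCCc1cn(CC(=O)O)c2c(/C=C/c3ccc(OCCCCc4c(F)ccc(F)c4F)cc3)cccc12`, gives 1.4 10^-6 cm/s in this assay. Compound 2, with structure `Cc1c(CCCC(=O)O)c2cccc(/C=C/c3ccc(OCCCCc4c(F)c(F)cc(F)c4F)cc3)c2n1CC(=O)O`, gives 9.4 10^-6 cm/s, the higher of the two numbers, and the gap between compound 2 and compound 1 is beyond the usual scatter. Among the measured compounds shown here, the two differ in several places, so no single step between them is defined.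

Compound 3, with structure `Cc1c(F)cccc1CCCCOc1ccc(/C=C/c2cccc3c(CCCC(=O)O)c(C)n(CC(=O)O)c23)cc1`, shares the core of compound 2 and differs from it only in the ring at the end of the chain: 3-fluoro-2-methylphenyl in place of 2,3,5,6-tetrafluorophenyl on a saturated chain carbon, four bonds along the chain from an oxygen on an aromatic ring. For the measured compounds named here, nothing measured so far isolates the effect of a change at this position, so the expectation rests on compound 2 alone. The step from compound 2 to compound 3 is expected to be small, a 1.3-fold lower number from compound 2 to compound 3 (0.13 log units; within the scatter), most likely within the scatter and, if anything, slightly downward. Compound 3 is therefore estimated at 7 10^-6 cm/s in this assay, with a range from 3 10^-6 cm/s to 15 10^-6 cm/s.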

Compound 3, apparent permeability: 4 10^-6 cm/s
The estimate for compound 3 lay 1.8-fold (0.24 log units) above the measured number; the measured number falls inside the stated range.
By their numbers in this assay, from the lowest: compound 1; then compound 3; then compound 2.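

In this assay, the ring at the end of the chain proves able to move the number: 3-fluoro-2-methylphenyl in place of 2,3,5,6-tetrafluorophenyl on a saturated chain carbon, four bonds along the chain from an oxygen on an aromatic ring, gives a 2.4-fold lower number from compound 2 to compound 3 (0.37 log units; beyond the scatter) and leaves the shared core untouched. This is the only pair shown that differs in one place, so it gives the only reading of a change at this position, which compound 1 and compound 2, differing in several places, could not give. Nothing shown bears on the reason for this step, and it stands as an observation only.

Among the compounds shown here, the single step cannot separate the departure of the fluorine atoms from the arrival of the methyl group, and it leaves open whether the same change would read alike on the core of compound 1. From the compounds shown here alone, how an unsubstituted phenyl, a pyridine or a cyclohexyl ring would read at this position, or a longer chain carrying the same ring, also remains open.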